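The source may report more compounds than this note shows. Statements on the series, on what has been measured and on what is new or still open speak of the compounds shown alone.

The measured compounds:

Compound 1, `Nc1ccccc1NC(=O)c1ccc(CSC(=S)N2CCN(c3ccccc3)CC2)cc1`, with 27.5% in a functional assay on A-375 cells (Homo sapiens) for antiproliferative activity, read by CCK-8 assay, with a stated time of 72 h, tested at 2 uM; on this read-out lower numbers stand for a weaker effect and higher numbers for a stronger effect at the one concentration tested.
Compound 2, `CCN(Cc1ccncc1)C(=S)SCc1ccc(C(=O)Nc2ccccc2N)cc1`, with 67.2% in this assay.

Of the two numbers, compound 2 stands highest, and its nearest neighbour is compound 1, whose value lies lower by a margin beyond the usual scatter. For the measured compounds named here, the two compounds share a core and differ in the amine carried on the thiocarbonyl carbon, but no single-point step between them is worked out, so their two values are taken as they stand.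

Compound 3, `CN1CCN(C(=S)SCc2ccc(C(=O)Nc3ccccc3N)cc2)CC1`, is the next compound to be measured. It differs from compound 2 in one place: 4-methylpiperazin-1-yl in place of ethyl((pyridin-4-yl)methyl)amino on a thiocarbonyl carbon. Going by the values given here, the group that enters is a ring, as is the group that compound 1 carries at the same position, and compound 1 gave 27.5%; that comparison is the only guide, and it points downward. The account therefore expects a step from compound 2 to compound 3 of a number 27.2 percentage points lower from compound 2 to compound 3 (beyond the scatter) in this assay, a loss beyond the scatter rather than a gain. For compound 3 the estimate in this assay is 40%, with a range from 15% to 65%.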

Compound 3, a percentage reported as inhibition, at one concentration (the size of the read-out at that concentration, not a potency): 36.6%
Compound 3: the middle estimate sits 3.4 percentage points above what was measured; measured number inside the range.
By their numbers in this assay, from the lowest: compounds 1 and 3 (each within the scatter of the next); then compound 2.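

In this assay, the position on the thiocarbonyl carbon now has a measured single-point step: 4-methylpiperazin-1-yl in place of ethyl((pyridin-4-yl)methyl)amino gives a large change (a number 30.6 percentage points lower from compound 2 to compound 3 (beyond the scatter)), so the value at this position depends on the amine attached there. Within the ring-bearing amines, methyl in place of phenyl on an amine nitrogen in a ring gives a much smaller step (a number 9.1 percentage points higher from compound 1 to compound 3 (within the scatter)), and the two compounds cannot be told apart in this read-out, so the group on that ring nitrogen shows no separable effect here. No measurement shown offers an explanation for either step.

The compounds shown leave open which part of ethyl((pyridin-4-yl)methyl)amino goes with the higher value, a question that a diethylamino or a benzyl(ethyl)amino group on the thiocarbonyl carbon could help to separate. Also open, from the compounds shown here alone, is whether another ring amine, such as morpholin-4-yl or piperidin-1-yl, would stand with the two ring-bearing compounds or nearer to the open-chain amine.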